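The source may hold more compounds than are shown below. What is called first, only, known or untested is meant among the compounds shown, and "the series" means these compounds.

Measured compounds:
compound 1, `Nc1cc(N)c2nc(-c3ccccc3)c(Oc3ccc(Cl)c(Cl)c3)nc2c1`, < 100000 nM
compound 2, `CCOC(=O)[C@H](CCC(=O)O)NC(=O)c1ccc(CNc2nc3cc(N)cc(N)c3nc2-c2ccccc2)cc1`, < 100000 nM
compound 3, `COc1ccc(CNc2nc3cc(N)cc(N)c3nc2-c2ccccc2)cc1OC`, 53700 nM

In a functional assay on CAKI-1 cells (Homo sapiens) for inhibition, read by sulforhodamine B assay, with a stated time of 48 h (on this read-out higher numbers stand for lower toxicity in this test and lower numbers for higher toxicity in this test), compound 1 gives < 100000 nM, which is a limit of the assay and not a number. For compound 2 the value < 100000 nM in this assay is likewise a limit. Only compound 3 gives a number in this assay, namely 53700 nM. Where compound 1 stands can therefore be told only roughly: it sits at the limit of < 100000 nM in this assay, at which 2 of the 3 values shown sit, and no two of the three compounds differ in a single place, so no measured step is available to lean on.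

The unmeasured compound 4, `Nc1cc(N)c2nc(-c3ccccc3)c(Sc3ccc(Cl)c(Cl)c3)nc2c1`, differs from compound 1 by (3,4-dichlorophenyl)sulfanyl in place of 3,4-dichlorophenoxy on an aromatic carbon. The group that leaves and the group that enters are counted alike in heavy atoms, ring, donors and acceptors. With compound 1 known only as a limit, the step is expected to amount to a step that the limit leaves unreadable from compound 1 to compound 4, no change beyond the usual scatter in either direction. Compound 4 is accordingly estimated at 60000 nM, with a range from 20000 nM to 150000 nM.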

Compound 4, concentration lethal to 50% of the cells: 89100 nM
Compound 4: the middle estimate sits 1.5-fold (0.17 log units) below what was measured, and the stated range covers the measured number.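

No step can be read from compound 1 to compound 4. In this assay compound 1 gives < 100000 nM, which is a limit of the assay and not a number. The compounds shown leave open whether (3,4-dichlorophenyl)sulfanyl in place of 3,4-dichlorophenoxy changes the read-out at all, and in which direction.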